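Working notes: amine-nitrogen substituent changes and metabolic half-life

This account rests on a few compounds, and the source may have more. Where it says the series, first, only, none or still open, it means among the compounds named here.

Measured so far:
compound 1, `CON/C(=N\C1=NC(=O)C(=O)N1C(C)C)Nc1ccc(Cl)c(Cl)c1`; in an in vitro ADME assay on microsomes from liver (Mus musculus) for metabolic stability, read by LC-MS (a higher number here means that the compound lasts longer, a lower number that the compound disappears faster), compound 1 gives > 1 h, a limit of the assay and not a number.
compound 2, `C=CCON/C(=N\C1=NC(=O)C(=O)N1C(C)C)Nc1ccc(Cl)c(Cl)c1`; in this assay compound 2 gives > 1 h, also a limit.
compound 3, `CC(C)N1C(=O)C(=O)N=C1/N=C(/Nc1ccc(Cl)c(Cl)c1)NC(C)(C)C`; in this assay compound 3 gives > 1 h, again a limit.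

Compound 3 therefore stands only at a limit, and so do the other two values shown (the limit of > 1 h in this assay, at which 3 of the 3 values shown sit). The steps among the three are accordingly unreadable: a step that the two limits leave unreadable from compound 1 to compound 2, a step that the two limits leave unreadable from compound 1 to compound 3 and a step that the two limits leave unreadable from compound 2 to compound 3. None of them gives a size or a direction.

Compound 4, `CC(C)N1C(=O)C(=O)N=C1/N=C(\NCCN(C)C)Nc1ccc(Cl)c(Cl)c1`, is not yet measured. It differs from compound 3 by 2-(dimethylamino)ethyl in place of tert-butyl on an amine nitrogen. For the measured compounds named here, the steps that bear on this change are the two that alter the group on the same amine nitrogen, a step that the two limits leave unreadable from compound 1 to compound 3 and a step that the two limits leave unreadable from compound 2 to compound 3, and both sit wholly at the limit, so nothing about the effect of exchanging that group can be read from them. No direction is therefore expected with any confidence, and the estimate rests on the limit at which compound 3 sits.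

Compound 4 is expected in this assay at about 1.2 h, within 0.5 h to 3 h. The corresponding expected step that the limit leaves unreadable from compound 3 to compound 4 is taken as within scatter, with a fair chance that the assay again reports only a limit for compound 4.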

Compound 4, half-life: > 1 h
Compound 4 gave a limit, no number; the forecaster's own chance of this, stated with the estimate: 55%; the middle value does not contradict the limit.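

In this assay compound 4 gives > 1 h, a limit of the assay and not a number. No new step can be read from compound 1, compound 2 or compound 3 to compound 4, as all the values sit at one limit: the limit of > 1 h in this assay, at which 4 of the 4 values shown sit.

The compounds shown leave open how long each actually lasts, and whether exchanging the group on the amine nitrogen changes the half-life at all.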